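Cyclohexylamino in place of phenoxy on the aminopyrimidine core

The source may hold more compounds than are shown below. What is called first, only, known or untested is meant among the compounds shown, and "the series" means these compounds.

Working notes on a small set of agonists tested in a functional assay on CHO cells for agonist activity at G-protein coupled receptor 39 (Homo sapiens), read by calcium flux; on this read-out lower numbers stand for an effect already at smaller amounts and higher numbers for an effect only at larger amounts of compound. Compound 1 `Cc1cc(N2CCCC2c2cccnc2)n2ncc(-c3ccccn3)c2n1` has two entries, 79 nM; 240 nM (2 entries), which sit within the usual scatter of each other (the several entries of compound 1 in this assay, 79 nM; 240 nM (2 entries)). Compound 2 `CNc1nc(NCc2ccccc2Cl)cc(-c2ccccn2)n1` gives 3 nM. Compound 3 `CNc1nc(Oc2ccccc2)cc(-c2ccccn2)n1` gives 481 nM, the highest number among the compounds with a single value; compound 2 lies far lower, beyond the scatter, while compound 1 has no single number to compare.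

Compound 4 `CNc1nc(NC2CCCCC2)cc(-c2ccccn2)n1` has not been measured. It differs from compound 3 by cyclohexylamino in place of phenoxy on an aromatic carbon. Among the measured compounds shown here, no measured pair in this set covers the same change, so the size of the step is uncertain. Compound 2, which also carries an amino link in this place and gives 3 nM, is taken as the nearer reference point, and the step from compound 3 to compound 4 is expected to be downward and beyond the scatter, a 12-fold lower number from compound 3 to compound 4 (1.08 log units; beyond the scatter). Compound 4 is estimated at 40 nM, with a range from 8 nM to 250 nM.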

Compound 4, half-maximal effective concentration: 16 nM
Compound 4: the middle estimate sits 2.5-fold (0.40 log units) above what was measured; the measured number falls inside the stated range.
By their numbers in this assay, from the lowest: compound 2; then compound 4; then compound 3.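

In this assay, cyclohexylamino in place of phenoxy gives a 30-fold lower number from compound 3 to compound 4 (1.48 log units; beyond the scatter), so an aromatic ring is not needed at this position for a low number, provided the link is an amino nitrogen. Among the compounds shown here, with compound 2 at 3 nM and compound 4 at 16 nM, both amino-linked compounds lie under compound 3, the only oxygen-linked member, though the change swaps the link atom, the ring type and the hydrogen-bond donor count together, and these three compounds alone carry this comparison. Nothing at hand on this series bears on why the step is this large.

As far as these compounds go, whether the link atom or the ring type carries the step stays open. Phenylamino or cyclohexyloxy at this place would separate the two.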